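A few compounds are considered here, and "the series" means these few. Any claim that something is new, unique, unknown or untested is made for them only; others in the source may bear on it.

In a functional assay on KB cells (Homo sapiens) for antiproliferative activity, read by sulforhodamine B assay, with a stated time of 3 days (on this read-out higher numbers stand for an effect only at larger amounts of compound and lower numbers for an effect already at smaller amounts), three compounds sharing one core have been measured. For the measured compounds named here, compound 1 `CCC1=C(O)c2c(oc(-c3ccc(C)cc3)cc2=O)C(CC)(CC)C1=O` gives 39.2 uM, the only actual number among them. Compound 2 `CCOc1ccc(-c2cc(=O)c3c(o2)C(CC)(CC)C(=O)C(CC)=C3O)cc1` gives only a limit, > 52.4 uM. On these data alone, compound 3 `CCC1=C(O)c2c(oc(-c3ccc(SC)cc3)cc2=O)C(CC)(CC)C1=O` also gives only a limit, > 52.1 uM, so its exact standing is unknown.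

Compound 4 `CCC1=C(O)c2c(oc(-c3cccc(C)c3)cc2=O)C(CC)(CC)C1=O` has 3-methylphenyl in place of the 4-(methylsulfanyl)phenyl of compound 3: 3-methylphenyl in place of 4-(methylsulfanyl)phenyl on an aromatic carbon. Going by the values given here, two measured steps bear on this change, an at least 1.3-fold higher number from compound 1 to compound 2 (0.12 log units; that floor lies within the scatter) and an at least 1.3-fold higher number from compound 1 to compound 3 (0.12 log units; that floor lies within the scatter). Each replaces a methyl group on an aromatic carbon, and neither has a readable size beyond its floor. The remaining step, a step that the two limits leave unreadable from compound 2 to compound 3, adds nothing. Compound 4 regains a methyl group, so a result close to that of compound 1 at 39.2 uM is expected. Another limit remains possible for compound 4. The expected step is an at least 1.3-fold lower number from compound 3 to compound 4 (0.11 log units; that floor lies within the scatter), estimated as small, towards a lower number, and measured against a limit. For compound 4 the estimated value is 40 uM, with an expected range of 22 uM to 70 uM.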

Compound 4, concentration for half-maximal effect: 49.7 uM
The estimate for compound 4 lay 1.2-fold (0.09 log units) below the measured number; the range from low to high includes it.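

In this assay, 3-methylphenyl in place of 4-methylphenyl gives a 1.3-fold higher number from compound 1 to compound 4 (0.10 log units; within the scatter), so the shared core now has a second actual number at this position, and the two methylphenyl compounds cannot be told apart. Against the two compounds without a number, the change reads only as an at least 1.0-fold lower number from compound 3 to compound 4 (0.02 log units; that floor lies within the scatter) and as an at least 1.0-fold lower number from compound 2 to compound 4 (0.02 log units; that floor lies within the scatter), floors that show no real change. Compound 3 remains a limit: the limit of > 52.1 uM in this assay, at which 1 of the 4 values shown sits.

On these data alone, compound 2 also remains a limit, so the true distance between its 4-ethoxyphenyl and the 3-methylphenyl of compound 4 stays open: the limit of > 52.4 uM in this assay, at which 1 of the 4 values shown sits. Also open, as far as these compounds go, is how an amine, a carboxylic acid or a longer chain in place of the methyl on this phenyl ring would read in this assay.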